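A few compounds are considered here, and "the series" means these few. Any claim that something is new, unique, unknown or untested is made for them only; others in the source may bear on it.

Measured so far in an ADME assay on microsomes from liver (Mus musculus) for metabolic stability; on this read-out lower numbers stand for a shorter-lived compound and higher numbers for a longer-lived compound:
- compound 1 `CC(C)C(Cc1nnc[nH]1)c1ccc(-c2ccc3cccc(F)c3c2)[nH]c1=O`: < 0.0667 h, which is a limit of the assay
- compound 2 `CC(C)C(c1ccc(-c2ccc3cccc(F)c3c2)[nH]c1=O)N1CCCCC1=O`: 0.0967 h
- compound 3 `CC(C)C(Nc1nccs1)c1ccc(-c2ccc3cccc(F)c3c2)[nH]c1=O`: 0.0733 h

Compound 3 stands at one of the two actual numbers on hand; compound 2 is its nearest neighbour, a 1.3-fold lower number from compound 2 to compound 3 (0.12 log units; within the scatter). The third value, that of compound 1, is a limit of the assay (the limit of < 0.0667 h in this assay, at which 1 of the 3 values shown sits).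

Compound 4 `CC(C)C(c1noc(=O)[nH]1)c1ccc(-c2ccc3cccc(F)c3c2)[nH]c1=O` differs from compound 3 at a single place: a group of 6 heavy atoms (2 carbon, 2 nitrogen, 2 oxygen; one five-membered aromatic ring with 3 hetero atoms) in place of a group of 6 heavy atoms (3 carbon, 2 nitrogen, 1 sulfur; one five-membered aromatic ring with 2 hetero atoms), on a saturated chain carbon bound to an aromatic carbon and a saturated chain carbon. The measured steps that bear on this all exchange the group on that same saturated chain carbon: an at least 1.0-fold higher number from compound 1 to compound 3 (0.04 log units; that floor lies within the scatter), an at least 1.4-fold higher number from compound 1 to compound 2 (0.16 log units; that floor lies within the scatter) and a 1.3-fold lower number from compound 2 to compound 3 (0.12 log units; within the scatter). Since each of these lies within the scatter and two of them rest on a limit, the exchange leading to compound 4 is expected to give no step beyond the scatter in either direction, a 1.0-fold higher number from compound 3 to compound 4 (0.01 log units; within the scatter). For compound 4 in this assay the estimate is 0.075 h, with a range from 0.045 h to 0.13 h; a result reported only as a limit remains possible given where compound 1 sits.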

Compound 4, half-life: > 3 h
Compound 4 ended at the assay's limit (the forecaster's own chance of this, stated with the estimate: 30%); middle value at least 40-fold (1.60 log units) from the limit.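

In this assay, the steps among compound 1, compound 2 and compound 3 showed nothing beyond the scatter, whereas this exchange on the saturated chain carbon gives an at least 40-fold higher number from compound 3 to compound 4 (1.61 log units; beyond the scatter), an at least 31-fold higher number from compound 2 to compound 4 (1.49 log units; beyond the scatter) and an at least 44-fold higher number from compound 1 to compound 4 (1.65 log units; beyond the scatter). Compound 4 gives > 3 h, which is a limit of the assay: the limit of > 3 h in this assay, at which 1 of the 4 values shown sits.

A five-membered aromatic ring with 3 hetero atoms is not enough on its own, since compound 1 also carries one, as (4H-1,2,4-triazol-3-yl)methyl, and stays at the low end of the series.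

As far as these compounds go, whether a carboxylic acid or a tetrazole on the same saturated chain carbon would behave like the group in compound 4 remains open. Also open, from the compounds shown here alone, is which part of the entering group carries the step, including its double bond outside the aromatic ring.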